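A few compounds are considered here, and "the series" means these few. Any claim that something is new, unique, unknown or untested is made for them only; others in the source may bear on it.

Measured in an ADME assay on a cell-free system (plasma, Rattus norvegicus) for protein binding:
- compound 1 `Cc1ccc(-c2cc(C(=O)N[C@H](C)c3ccc(C(F)(F)F)[n+]([O-])c3)cc(C(C)(C)O)c2)nc1`: 62.4%
- compound 2 `Cc1ccc(-c2cc(C(=O)N[C@H](C)c3ccc(C(F)(F)F)nc3)cc(-c3ncccc3F)c2)nc1`: 98.6%

Of these two, compound 2 stands at the high end of this assay, with 98.6% and the lower unbound fraction. Its gap to compound 1 is beyond the scatter, but the two compounds differ in more than one place, so no single change can be read from that gap.

Compound 3 `Cc1ccc(-c2cc(C(=O)N[C@H](C)c3ccc(F)c[n+]3[O-])cc(-c3ncccc3F)c2)nc1` is not yet measured. It derives from compound 2 by one change: a group of 8 heavy atoms (5 carbon, 1 nitrogen, 1 oxygen, 1 fluorine; one six-membered aromatic ring with 1 hetero atom) in place of a group of 10 heavy atoms (6 carbon, 1 nitrogen, 3 fluorine; one six-membered aromatic ring with 1 hetero atom), on a saturated chain carbon bound to an amide-type nitrogen and a saturated chain carbon. The rest of the structure stays as in compound 2.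

Among the compounds with values here, no measured pair isolates this change. Within the data shown here, the only guide is compound 1, which also carries an oxygen in the aromatic ring at this place and shows 62.4%. That compound is a weak guide, since it differs from compound 3 elsewhere too. A drop in binding is therefore expected, though not one reaching the level of compound 1. The expected size is a 7.1-fold higher unbound fraction from compound 2 to compound 3 (0.85 log units; beyond the scatter), towards more free compound and probably beyond the scatter.

For compound 3 the estimate is 90%, with an expected range from 78% to 96.5%.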

Compound 3, plasma protein binding: 90.4%
For compound 3 the middle estimate is 1.0-fold (0.02 log units) (unbound fraction) above the measured one, and the stated range covers the measured number.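

In this assay, the group on the saturated chain carbon bound to an amide-type nitrogen and a saturated chain carbon now has its first isolated reading: with the rest of the structure unchanged, replacing 6-(trifluoromethyl)pyridin-3-yl with the ring carrying oxygen and fluorine gives a 6.9-fold higher unbound fraction from compound 2 to compound 3 (0.84 log units; beyond the scatter), so this single change moves the read-out beyond the scatter. The change does not bring the read-out close to a low level, as compound 3 still gives 90.4%. The data shown offer no measurement that accounts for this step.

The step changes the ring substituent and adds the oxygen together, so the compounds shown do not separate the contribution of the trifluoromethyl-to-fluorine exchange from that of the ring oxygen. Also open, as far as these compounds go, are whether the same step holds when the rest of the core differs, and how a ring carrying an amine or a carboxylic acid at this place would stand in this assay.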